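Exchanging Chloro for Methyl in a Growth Inhibition Series

A few compounds are considered here, and "the series" means these few. Any claim that something is new, unique, unknown or untested is made for them only; others in the source may bear on it.

In a functional assay on MCF7 cells (Homo sapiens) for inhibition, read by sulforhodamine B assay, with a stated time of 48 h (on this read-out lower numbers stand for stronger inhibition of growth and higher numbers for weaker inhibition of growth), compound 3 `CC(C)(C)NCc1c(C(=O)O)nn(-c2ccc(Cl)cc2)c1-c1ccc(Cl)cc1` gives 246000 nM. Compound 2 `CC(C)(C)NCc1c(C(=O)O)nn(-c2ccc(Cl)cc2)c1-c1ccc(F)cc1` gives 270000 nM, and these two values lie within the scatter of each other, so neither compound can be ranked over the other. Compound 1 `CCOC(=O)c1nn(-c2ccc(Cl)cc2)c(-c2ccc(C)cc2)c1CNC(C)(C)C` gives 141000 nM; > 542000 nM (2 entries) in this assay. The second of the entries for compound 1 is a limit of the assay and not a number.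

Compound 4 `Cc1ccc(-c2c(CNC(C)(C)C)c(C(=O)O)nn2-c2ccc(Cl)cc2)cc1` differs from compound 3 in one place: methyl in place of chloro on an aromatic carbon. Seen one bond further out, the change turns 4-chlorophenyl into 4-methylphenyl.

Among the compounds with values here, one measured step bears on this change: a 1.1-fold lower number from compound 2 to compound 3 (0.04 log units; within the scatter). It too exchanges one group for another on an aromatic carbon, although it puts chloro in place of fluoro and no methyl is involved, so it offers only limited guidance. With that single exchange staying within the scatter, no step beyond the scatter is expected in this assay. The estimated change is a 1.0-fold higher number from compound 3 to compound 4 (0.01 log units; within the scatter). For compound 4 the expected value is 250000 nM, with an estimated range from 130000 nM to 480000 nM.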

Compound 4, concentration for 50% growth inhibition: > 629000 nM
Compound 4: a limit, no number; the forecaster's own chance of this, stated with the estimate: 15%; at least 2.5-fold (0.40 log units) between middle value and limit.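

In this assay compound 4 gives > 629000 nM, which is a limit of the assay and not a number. Fluoro and chloro on this aromatic carbon could not be told apart, whereas methyl can be told from both, with an at least 2.5-fold higher number from compound 3 to compound 4 (0.40 log units; beyond the scatter) and an at least 2.3-fold higher number from compound 2 to compound 4 (0.36 log units; beyond the scatter). This place on the six-membered aromatic ring, para to a large group, therefore responds to the group it carries, in the direction of weaker inhibition of growth, although the full size of both steps stays unknown, as all that is available for compound 4 is: the limit of > 629000 nM in this assay, at which 1 of the 4 values shown sits.

The compounds shown leave open whether methyl stands apart from the two halogens on its own or whether other groups on this carbon, such as methoxy or an amine, would also shift the number. They also leave open how the ethyl ester of compound 1 compares with the carboxylic acid of compound 4, since compound 1 offers no single number: the several entries of compound 1 in this assay, 141000 nM; > 542000 nM (2 entries)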